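The source may hold more compounds than are shown below. What is called first, only, known or untested is meant among the compounds shown, and "the series" means these compounds.

Three compounds share one core and one long chain: compound 3 `O=C1c2ccccc2S(=O)(=O)N1CCCCCCN1CCN(c2ccccc2)CC1`, compound 1 `COc1cccc(N2CCN(CCCCCCN3C(=O)c4ccccc4S3(=O)=O)CC2)c1` and compound 2 `O=C1c2ccccc2S(=O)(=O)N1CCCCCCN1CCN(c2cccc(C(F)(F)F)c2)CC1`. In an ADME assay on HEK293 cells for displacement of a labelled ligand from 5-hydroxytryptamine receptor 6 (Homo sapiens), read by radioligand binding, with a stated time of 1 h (a higher number here means a weaker inhibitor, a lower number a stronger inhibitor), compound 3 gives 971 nM, the highest of the three numbers; compound 1 gives 921 nM, a value within the scatter of compound 3, while compound 2 gives 52 nM. The measured steps all concern a substituent on an aromatic carbon: an 18-fold lower number from compound 1 to compound 2 (1.25 log units; beyond the scatter), a 19-fold higher number from compound 2 to compound 3 (1.27 log units; beyond the scatter) and a 1.1-fold higher number from compound 1 to compound 3 (0.02 log units; within the scatter). Compound 4 `O=C1c2ccccc2S(=O)(=O)N1CCCCCCN1CCN(c2cccc3cccnc23)CC1` differs from compound 3 in another place: quinolin-8-yl in place of phenyl on an amine nitrogen in a ring. Among the compounds with values here, no measured step shows this kind of change, so only a cautious expectation is possible. Compound 4 is expected to give 400 nM, between 80 nM and 2000 nM, which would mean an estimated 2.4-fold lower number from compound 3 to compound 4 (0.39 log units; beyond the scatter).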

Compound 4, inhibition constant: 1720 nM
Beside the measured number, compound 4's estimate is 4.3-fold (0.63 log units) below it; measured number inside the range.
By their numbers in this assay, from the lowest: compound 2; then compounds 1, 3 and 4 (each within the scatter of the next).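

In this assay quinolin-8-yl on the amine nitrogen in the ring gives a 1.8-fold higher number from compound 3 to compound 4 (0.25 log units; within the scatter) in place of phenyl and a 1.9-fold higher number from compound 1 to compound 4 (0.27 log units; within the scatter) in place of 3-methoxyphenyl so this two-ring group does not separate these three compounds. In place of 3-(trifluoromethyl)phenyl it gives a 33-fold higher number from compound 2 to compound 4 (1.52 log units; beyond the scatter) so of the groups tried here, only 3-(trifluoromethyl)phenyl stands apart. Nothing available explains this difference. Still open, on these data alone, is whether a chloro or nitrile group on the phenyl ring would match trifluoromethyl, and whether quinolin-8-yl would behave the same on a shorter chain.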